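Sulfo Removal from Compound 2

A few compounds are considered here, and "the series" means these few. Any claim that something is new, unique, unknown or untested is made for them only; others in the source may bear on it.

Compound 1 `CC(=O)N[C@H]1[C@@H](OCCCCc2ccccc2)O[C@H](CO)[C@@H](O)[C@@H]1O`: > 50 uM (a limit)
Compound 2 `CCCCCCCCCCCCCCCCO[C@H]1O[C@H](COCC(CO)(CO)COS(=O)(=O)O)[C@@H](O)[C@H](O)[C@H]1NC(=O)CCCC`: 11 uM

Going by the values given here, in a functional assay on C6 cells (Rattus norvegicus), read by thymidine incorporation (a lower number here means a stronger inhibitor, a higher number a weaker inhibitor), compound 2 gives 11 uM, the only actual number so far. The > 50 uM of compound 1 is a limit of the assay, so it gives no exact value for comparison.

Compound 3 `CCCCCCCCCCCCCCCCO[C@H]1O[C@H](COCC(CO)(CO)CO)[C@@H](O)[C@H](O)[C@H]1NC(=O)CCCC` differs from compound 2 at one place, with hydrogen in place of sulfo on an oxygen on a saturated carbon. Among the compounds with values here, no measured pair isolates this change, so its size in this assay can only be estimated. Compound 1 also carries no sulfo, but it differs from compound 2 in other ways too, so it offers only weak guidance. A modest loss of inhibition is expected, though a result within the scatter would be no surprise. The expected change is a 2.3-fold higher number from compound 2 to compound 3 (0.36 log units; beyond the scatter). For compound 3 the estimated value is 25 uM, with an expected range of 9 uM to 70 uM.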

Compound 3, concentration for 50% inhibition: 18.3 uM
The estimate for compound 3 lay 1.4-fold (0.14 log units) above the measured number; the range from low to high includes it.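

In this assay, going by these compounds alone, the first pair to isolate this change gives a 1.7-fold higher number from compound 2 to compound 3 (0.22 log units; within the scatter), so taking sulfo off this oxygen on a saturated carbon leaves a step that cannot be told from repeat measurement. Compound 3 still gives a measured value of 18.3 uM, which shows that a readable number in this assay does not depend on the sulfooxy group on this scaffold. Nothing given here explains the size of this step.

The compounds shown carry only sulfooxy and hydroxy at this place, so it remains open how an amine, a carboxylic acid or a methyl ether there would read. From the compounds shown here alone, it is also open whether the same change would behave alike on the core of compound 1, whose only entry is a limit.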